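The compounds below may be only part of what the source reports. "The series", "measured", "known", "first", "only" and "open" are said of these compounds alone.

Measured compounds:
compound 1 `CCCCCCCCCCCC[C@@H](O)[C@H]1CC[C@H]([C@H](O)CCCCCCCCCCNC(=O)c2cncs2)O1` — 832 nM
compound 2 `CCCCCCCCCCCC[C@@H](O)[C@H]1CC[C@H]([C@H](O)CCCCCCCCCCNC(=O)c2ccnn2C)O1` — 10 nM

In a functional assay on MKN-28 cells (Homo sapiens) for inhibition, read by colorimetric assay and sulforhodamine B assay, with a stated time of 48 h (on this read-out lower numbers stand for stronger inhibition of growth and higher numbers for weaker inhibition of growth), compound 1 gives 832 nM and stands highest of the two numbers. Compound 2 gives 10 nM. Among the measured compounds shown here, the only measured step, an 83-fold lower number from compound 1 to compound 2 (1.92 log units; beyond the scatter), changes the group on the carbonyl carbon and is large.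

Compound 3 `CCCCCCCCCCCC[C@@H](O)[C@H]1CC[C@H]([C@H](O)CCCCCCCCCCNC(=O)c2cccs2)O1` is not yet measured. It differs from compound 1 as follows: thiophen-2-yl in place of 1,3-thiazol-5-yl on a carbonyl carbon. For the measured compounds named here, no measured step matches this change; the step from compound 1 to compound 2 concerns the same position but a different group, so it sets only the scale of what such a change can do. Compound 3 is expected to give about 600 nM, with a range of 100 nM to 3000 nM. The expected step is a 1.4-fold lower number from compound 1 to compound 3 (0.14 log units; within the scatter), which is no more than a small change from compound 1.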

Compound 3, concentration for 50% growth inhibition: 363 nM
Compound 3: the middle estimate sits 1.7-fold (0.22 log units) above what was measured; the measured number falls inside the stated range.
By their numbers in this assay, from the lowest: compound 2; then compound 3; then compound 1.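

Thiophen-2-yl in place of 1,3-thiazol-5-yl gives a 2.3-fold lower number from compound 1 to compound 3 (0.36 log units; beyond the scatter) in this assay and shows that a ring with 1 hetero atom and one with 2 can differ only modestly at this position. The other new step, a 36-fold higher number from compound 2 to compound 3 (1.56 log units; beyond the scatter) in this assay and large, keeps 1-methyl-1H-pyrazol-5-yl clearly lowest, with both sulfur-bearing rings well behind it.

Open, going by these compounds, is how a phenyl ring or an unmethylated 1H-pyrazol-5-yl on the same carbonyl carbon would compare. No measurement here accounts for these gaps.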